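A few compounds are considered here, and "the series" means these few. Any claim that something is new, unique, unknown or untested is made for them only; others in the source may bear on it.

Compound 1 `Cc1c(-c2ccccc2)[nH]n(-c2nc3ccccc3[nH]2)c1=O`: -11%
Compound 2 `Cc1[nH]n(-c2nc3ccccc3[nH]2)c(=O)c1Cc1ccc(Cl)cc1Cl`: 11%

Of the compounds shown here, two have been measured so far. In an assay on isolated protein for inhibition of alpha-ketoglutarate-dependent dioxygenase alkB homolog 3 (Homo sapiens), read by polymerase chain reaction, with a stated time of 1 h, tested at 10 mM (on this read-out higher numbers stand for more inhibition at the one concentration tested (going by the name of the read-out) and lower numbers for less inhibition), compound 1 gives -11%, the lowest of the two numbers. Within the data shown here, compound 2 gives 11%, and the gap between these two values lies beyond the usual scatter; no step between them has been worked out, so only the two values themselves can be said. Compound 3 `O=c1c(Cc2ccccc2)c(-c2ccccc2)[nH]n1-c1nc2ccccc2[nH]1` has not yet been measured. It differs from compound 1 by phenyl in place of hydrogen on a saturated chain carbon bound to an aromatic carbon. In this assay the change is expected to bring a small upward step, a number 16 percentage points higher from compound 1 to compound 3 (beyond the scatter), close to the edge of the scatter. Compound 3 is therefore estimated at 5%, within a range from -15% to 25%.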

Compound 3, a percentage reported as inhibition, at one concentration (the size of the read-out at that concentration, not a potency): 2%
For compound 3 the middle estimate is 3 percentage points above the measured one, within the range that was stated.
By their numbers in this assay, from the lowest: compound 1; then compounds 3 and 2 (each within the scatter of the next).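

Putting phenyl in place of hydrogen on the saturated chain carbon bound to an aromatic carbon, which reads as methyl to benzyl, gives in this assay a modest change (a number 13 percentage points higher from compound 1 to compound 3 (beyond the scatter)), so the read-out does respond to a change at this position. Even with the added ring, compound 3 reaches only 2% on this read-out. Nothing available gives a cause for this step. The compounds shown leave open whether an amine, a carboxylic acid or a longer chain at this place would shift the number further.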